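The source may report more compounds than this note shows. Statements on the series, on what has been measured and on what is new or still open speak of the compounds shown alone.

Measured so far in a functional assay on B16 cells (Mus musculus) for antiproliferative activity, read by MTT assay, with a stated time of 24 h; a higher number here means a weaker inhibitor, a lower number a stronger inhibitor:
compound 1 `COc1cccc(C(=O)Oc2ccc3c(=O)c(-c4cc(OC)c(OC)cc4OC)coc3c2)c1` gives > 10000 nM, which is a limit of the assay and not a number.
compound 2 `COc1cc(OC)c(-c2coc3cc(OCc4ccc(Br)cc4)ccc3c2=O)cc1OC` gives 1180 nM.
compound 3 `COc1cc(OC)c(-c2coc3cc(OCc4cccc(F)c4)ccc3c2=O)cc1OC` gives 2440 nM.

Compound 1 thus stands only at a floor, (the limit of > 10000 nM in this assay, at which 1 of the 3 values shown sits), and its true number is not known. Compound 4 `COc1cc(OC)c(-c2coc3cc(OCc4ccccc4Cl)ccc3c2=O)cc1OC` differs from compound 1 in one place: 2-chlorobenzyl in place of (3-methoxyphenyl)carbonyl on an oxygen on an aromatic ring. Among the measured compounds shown here, two measured steps bear on this change, each trading the same leaving group for a benzyl carrying a single halogen: an at least 8.4-fold lower number from compound 1 to compound 2 (0.92 log units; beyond the scatter) and an at least 4.0-fold lower number from compound 1 to compound 3 (0.61 log units; beyond the scatter). Between those two products, a 2.1-fold higher number from compound 2 to compound 3 (0.32 log units; beyond the scatter). A drop of comparable size is therefore expected for the new step, an at least 5.5-fold lower number from compound 1 to compound 4 (0.74 log units; beyond the scatter). Compound 4 is estimated at 1800 nM, with a range from 800 nM to 4500 nM.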

Compound 4, half-maximal inhibitory concentration: 4180 nM
For compound 4 the middle estimate is 2.3-fold (0.37 log units) below the measured one, and the stated range covers the measured number.
By their numbers in this assay, from the lowest: compound 2; then compounds 3 and 4 (each within the scatter of the next). At a limit, above all of these: compound 1.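

Replacing the (3-methoxyphenyl)carbonyl with 2-chlorobenzyl also lowers the number, an at least 2.3-fold lower number from compound 1 to compound 4 (0.37 log units; beyond the scatter), so a third halogen-bearing benzyl follows the same direction. For compound 1, this step starts from a limit and not a number: the limit of > 10000 nM in this assay, at which 1 of the 4 values shown sits. On the benzyl ring, 2-chlorophenyl is not separated from 3-fluorophenyl, a 1.7-fold higher number from compound 3 to compound 4 (0.23 log units; within the scatter), but it is separated from 4-bromophenyl, a 3.5-fold higher number from compound 2 to compound 4 (0.55 log units; beyond the scatter).

These three benzyl groups differ in both halogen and ring place, so the two cannot be told apart. Going by these compounds, whether an amine or a carboxylic acid on that ring would keep the number low also remains open.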